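A morpholin-4-yl swap starting from an assay limit

A few compounds are considered here, and "the series" means these few. Any claim that something is new, unique, unknown or untested is made for them only; others in the source may bear on it.

Of the compounds shown here, three sharing one core have been tested in a functional assay on HCT-116 cells (Homo sapiens) for antiproliferative activity, read by MTT assay, with a stated time of 72 h; a higher number here means a weaker inhibitor, a lower number a stronger inhibitor. Compound 1 `C=CC(=O)N(CC(=O)OCC)c1nc(-c2ccccc2)cs1` gives > 30000 nM, which is a limit and not a number. Compound 2 `C=CC(=O)N(CC(=O)OC)c1nc(-c2ccccc2)cs1` gives > 30000 nM, again a limit. Compound 3 `C=CC(=O)N(CC(=O)O)c1nc(-c2ccccc2)cs1`, which carries the carboxy group, gives > 30000 nM, also a limit. The whole set therefore sits at one mark: the limit of > 30000 nM in this assay, at which 3 of the 3 values shown sit.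

Compound 4 `C=CC(=O)N(CC(=O)N1CCOCC1)c1nc(-c2ccccc2)cs1` keeps the core and changes one group, with morpholin-4-yl in place of hydroxy on a carbonyl carbon. The same difference reads as carboxy to (morpholin-4-yl)carbonyl.

The measured steps that bear on this change all fall on the same carbonyl group. There is a step that the two limits leave unreadable from compound 1 to compound 2, there is a step that the two limits leave unreadable from compound 1 to compound 3, and there is a step that the two limits leave unreadable from compound 2 to compound 3. Among the compounds with values here, none of the three offers a size to carry over, and no compound in the set has yet given an actual number. Within the data shown here, no step of a known size can be expected in this assay, so the likeliest result is another limit, although a lower number cannot be ruled out. The expected change is a number no higher from compound 3 to compound 4 (the limit leaves the size open). For compound 4 the estimate is 30000 nM, with an expected range from 10000 nM to 60000 nM.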

Compound 4, half-maximal inhibitory concentration: 14600 nM
Estimate against measurement, compound 4: 2.1-fold (0.31 log units) above; measured number inside the range.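

In this assay, the group on this carbonyl carbon turns out to matter: morpholin-4-yl in place of hydroxy gives an at least 2.0-fold lower number from compound 3 to compound 4 (0.31 log units; beyond the scatter) and in place of methoxy gives an at least 2.0-fold lower number from compound 2 to compound 4 (0.31 log units; beyond the scatter) and in place of ethoxy gives an at least 2.0-fold lower number from compound 1 to compound 4 (0.31 log units; beyond the scatter). Each of these steps starts from a limit, so the real size could be larger, but all three lie beyond the scatter, whereas the steps among compound 1, compound 2 and compound 3 cannot be read. The earlier compounds shown here could not show any of this, because none of them gave an actual number: the limit of > 30000 nM in this assay, at which 3 of the 4 values shown sit.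

Going by these compounds, what remains open is which part of the change counts, since morpholin-4-yl differs from hydroxy, methoxy and ethoxy in bringing both a ring and a nitrogen to the carbonyl carbon. A piperidin-1-yl group, which has the ring without its oxygen, or an open-chain dimethylamino group, which has the nitrogen without any ring, could help separate these features, and compound 4 alone cannot show whether further gains are possible at this position.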